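This account rests on a few compounds, and the source may have more. Where it says the series, first, only, none or still open, it means among the compounds named here.

Measured so far:
- Compound 1 `CC(Cn1ncccc1=O)C(=N)S`. In a functional assay on the whole organism (stomach) with Rattus norvegicus as the target (on this read-out lower numbers stand for an effect already at smaller amounts and higher numbers for an effect only at larger amounts of compound), compound 1 gives > 100 mg/kg, which is a limit of the assay and not a number.
- Compound 2 `N=C(S)CCn1ncccc1=O`. In this assay compound 2 gives > 100 mg/kg, again only a limit of the assay.

Compound 1 therefore stands nowhere on a scale of numbers: both values shown sit at the limit of > 100 mg/kg in this assay, at which 2 of the 2 values shown sit. Within the data shown here, the one measured step, a step that the two limits leave unreadable from compound 1 to compound 2, is left unreadable by the two limits, so its size is unknown.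

Compound 3 `C/N=C(\S)C(C)Cn1ncccc1=O` differs from compound 1 by a group of 4 heavy atoms (2 carbon, 1 nitrogen, 1 sulfur; no ring) in place of a group of 3 heavy atoms (1 carbon, 1 nitrogen, 1 sulfur; no ring), on a saturated chain carbon bound to two saturated chain carbons. Among the measured compounds shown here, no measured step bears on this change; the single step recorded, between the two limits, gives no direction and no size to carry over. With nothing read on either side, no step beyond the scatter is expected for a number no higher from compound 1 to compound 3 (the limit leaves the size open), and compound 3 is most likely to return another limit.

Estimate for compound 3 in this assay: expected value 100 mg/kg, with a range from 30 mg/kg to 300 mg/kg.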

Compound 3, dose for half-maximal effect: 100 mg/kg
Estimate against measurement, compound 3: no gap at the digits printed; measured number inside the range.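

In this assay, among these compounds, compound 3 gives 100 mg/kg, the first actual number. Among the compounds shown here, with a group of 4 heavy atoms in place of a group of 3 heavy atoms, on a saturated chain carbon bound to two saturated chain carbons, the result is a number no higher from compound 1 to compound 3 (the limit leaves the size open), so this change can yield a number where the earlier compounds gave only limits, though the size of the step cannot be read. The other values remain limits and not numbers: the limit of > 100 mg/kg in this assay, at which 2 of the 3 values shown sit.

Going by these compounds, whether an amine or a longer chain in place of this group, on the same saturated chain carbon, gives a clearly lower number than compound 3 stays open. Also open, on these data alone, is whether the group of 4 heavy atoms yields a number on the core of compound 2, which has hydrogen in place of methyl.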